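Chloro on the benzoyl ring of compound 3

The source may hold more compounds than are shown below. What is called first, only, known or untested is meant among the compounds shown, and "the series" means these compounds.

Three compounds of a shared core have been measured in a functional assay on ACHN cells (Homo sapiens) for cytotoxicity, read by sulforhodamine B assay, with a stated time of 72 h; on this read-out lower numbers stand for stronger inhibition of growth and higher numbers for weaker inhibition of growth:

Compound 1, `O=C(Nc1ccccc1O)C1CCc2ccccc2N1C(=O)c1ccc(Cl)cc1`, gives 19600 nM.
Compound 2, `CCCCCCCCC(=O)N1c2ccccc2CCC1C(=O)Nc1ccccc1C(F)(F)F`, gives 8330 nM.
Compound 3, `O=C(Nc1ccccc1C(F)(F)F)C1CCc2ccccc2N1C(=O)c1ccccc1`, gives 8090 nM.

Compound 3 holds the lowest number of the three in this assay. Compound 2 sits closest to it, and the step of a 1.0-fold lower number from compound 2 to compound 3 (0.01 log units; within the scatter) lies within the scatter. Compound 1 sits furthest, with a number beyond the scatter above compound 3; compound 1 differs from compound 3 in two places, so its two values say only that much.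

Compound 4, `O=C(Nc1ccccc1C(F)(F)F)C1CCc2ccccc2N1C(=O)c1ccc(Cl)cc1`, has not yet been measured. It differs from compound 3 by chloro in place of hydrogen on an aromatic carbon. Within the data shown here, no measured step matches this change. Among the measured compounds shown here, the only step available, a 1.0-fold lower number from compound 2 to compound 3 (0.01 log units; within the scatter), exchanges the whole group on the carbonyl carbon and barely moves the number. Compound 1 carries the same chloro but also a different group on the aniline ring, so it is no guide to the chloro alone.

For the measured compounds named here, with no step of its own kind to lean on, the expectation for compound 4 in this assay is a number near that of compound 3, the step of a 1.0-fold lower number from compound 3 to compound 4 (0.00 log units; within the scatter) being expected to fall within the scatter. Compound 4 is thus estimated at 8000 nM, with a range from 3000 nM to 22000 nM.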

Compound 4, concentration for 50% growth inhibition: 824 nM
Compound 4: the middle estimate sits 9.7-fold (0.99 log units) above what was measured; measured number below the stated range.
By their numbers in this assay, from the lowest: compound 4; then compounds 3 and 2 (each within the scatter of the next); then compound 1.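

In this assay, one chloro para to a large group on the benzoyl ring accounts for a 9.8-fold lower number from compound 3 to compound 4 (0.99 log units; beyond the scatter) in this series, which shows that this position on the aromatic ring can respond strongly to a single added atom. The earlier step of a 1.0-fold lower number from compound 2 to compound 3 (0.01 log units; within the scatter) gave no sign of this, as phenyl and octyl on the carbonyl carbon stood level, whereas the exchange of octyl for 4-chlorophenyl gives a 10-fold lower number from compound 2 to compound 4 (1.00 log units; beyond the scatter) and so ties the gain to the chloro-bearing ring and not to an aromatic ring alone. With that 4-chlorophenyl group held constant, the aniline ring also matters, since trifluoromethyl in place of hydroxy gives a 24-fold lower number from compound 1 to compound 4 (1.38 log units; beyond the scatter) in the same read-out.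

The compounds shown leave open whether fluoro, bromo, methyl or methoxy at this place would give a similar gain, and whether chloro elsewhere on the ring would do the same. The data at hand offer no explanation for the size of the chloro step.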